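This account rests on a few compounds, and the source may have more. Where it says the series, first, only, none or still open, it means among the compounds named here.

Measured in an ADME assay on NHDF cells (Homo sapiens) for cytotoxicity, read by MTT assay, with a stated time of 72 h; on this read-out higher numbers stand for weaker inhibition and lower numbers for stronger inhibition:

compound 1 `COc1ccc(/C=C2\CCC/C(=C\c3ccc(OC)c(OC)c3)C2=O)cc1` — 30900 nM
compound 2 `COc1ccc(/C=C2\CCC/C(=C\c3ccc(OC)c(OC)c3)C2=O)c(OC)c1` — > 50000 nM, a limit of the assay
compound 3 `COc1ccc(/C=C2\CCC/C(=C\c3ccc(OC)c(OC)c3)C2=O)cc1OC` — 9700 nM

Compound 1 gives the highest of the two numbers; compound 3 sits below it, with a 3.2-fold lower number from compound 1 to compound 3 (0.50 log units; beyond the scatter). For compound 2 only a limit is known, (the limit of > 50000 nM in this assay, at which 1 of the 3 values shown sits). Compound 4 `COc1ccc(/C=C2\CCC/C(=C\c3ccc(O)c(O)c3)C2=O)cc1OC` differs from compound 1 as 3,4-dihydroxyphenyl in place of 4-methoxyphenyl on a double-bonded chain carbon bound to a double-bonded ring carbon. Neither measured step matches this change: both add a methoxy rather than remove one, and they run in opposite directions, an at least 1.6-fold higher number from compound 1 to compound 2 (0.20 log units; that floor lies within the scatter) against a 3.2-fold lower number from compound 1 to compound 3 (0.50 log units; beyond the scatter). No step beyond the scatter is therefore expected for compound 4, giving a 1.0-fold lower number from compound 1 to compound 4 (0.01 log units; within the scatter). Compound 4 is estimated at 30000 nM, within 10000 nM to 90000 nM.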

Compound 4, half-maximal inhibitory concentration: 25200 nM
Beside the measured number, compound 4's estimate is 1.2-fold (0.08 log units) above it, within the range that was stated.
By their numbers in this assay, from the lowest: compound 3; then compounds 4 and 1 (each within the scatter of the next). At a limit, above all of these: compound 2.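

In this assay, 3,4-dihydroxyphenyl in place of 4-methoxyphenyl gives a 1.2-fold lower number from compound 1 to compound 4 (0.09 log units; within the scatter). For the compounds shown here, earlier steps at this place only added a methoxy; this one is the first to remove the methoxy and bring in hydroxyl groups, with hydrogen-bond donors where compound 1 has none, and compounds 1 and 4 cannot be told apart here. Nothing shown gives a cause for this outcome.

Still open, from the compounds shown here alone, is how a single hydroxyl, an amine or a carboxylic acid at this place would read in this assay.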